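The compounds below may be only part of what the source reports. "The series", "measured", "known", "first", "only" and "open" are said of these compounds alone.

Compound 2 `O=C1/C(=C/c2ccccc2)CCC/C1=C\c1ccccc1Br` stands highest of the two numbers in an assay on isolated protein for inhibition of Alpha glucosidase (Homo sapiens), with stated times of 5 min and 15 min, tested at 50 uM (on this read-out lower numbers stand for less inhibition and higher numbers for more inhibition at the one concentration tested (going by the name of the read-out)), where compound 2 gives 46.8%. Within the data shown here, compound 1 `O=C1/C(=C/c2ccccc2)CCC/C1=C\c1ccc(Br)cc1` gives 29.1%, and the single measured step, a number 17.7 percentage points higher from compound 1 to compound 2 (beyond the scatter), came with 2-bromophenyl in place of 4-bromophenyl. Compound 3 `O=C1/C(=C/c2ccccc2)CCC/C1=C\c1ccccc1Cl` differs from compound 2 by chloro in place of bromo on an aromatic carbon. Among the measured compounds shown here, no measured step concerns an exchange of one halogen for another at the same place, so the data give no direction for this change. Compound 3 is therefore expected to show no step beyond the scatter, a number 2.8 percentage points lower from compound 2 to compound 3 (within the scatter), with an estimate of 44% spanning 28% to 60%.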

Compound 3, a percentage reported as inhibition, at one concentration (the size of the read-out at that concentration, not a potency): 43%
For compound 3 the middle estimate is 1 percentage points above the measured one, within the range that was stated.
By their numbers in this assay, from the lowest: compound 1; then compounds 3 and 2 (each within the scatter of the next).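

At this place on the aromatic ring, ortho to a large group, chloro in place of bromo gives no change that can be told apart in this assay (a number 3.8 percentage points lower from compound 2 to compound 3 (within the scatter)). The 2-chlorophenyl compound also stands clear of the 4-bromophenyl compound (a number 13.9 percentage points higher from compound 1 to compound 3 (beyond the scatter)), so the rise seen with 2-bromophenyl is not tied to bromo alone. Nothing measured here explains either step. The compounds shown leave open whether an amine or a methoxy group at this place would keep the read-out in the range of chloro and bromo.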